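The source may report more compounds than this note shows. Statements on the series, on what has been measured and on what is new or still open speak of the compounds shown alone.

Compound 3 `CC(=O)Nc1ccc(S(=O)(=O)Nc2cccc(-c3nc(-c4ccc(NC(=O)c5cccnc5)cc4Cl)no3)c2)cc1Cl` belongs to a small set built on one shared core. In a functional assay on MDA-MB-231 cells (Homo sapiens) for antiproliferative activity, read by MTT assay, with a stated time of 72 h (a lower number here means a stronger inhibitor, a higher number a weaker inhibitor), compound 3 gives only a limit of the assay, > 10000 nM, not a number. Compound 1 `O=C(Nc1ccc(-c2noc(-c3cccc(NS(=O)(=O)c4cccc(Cl)c4)c3)n2)c(Cl)c1)c1cccnc1` also gives only a limit in this assay, > 10000 nM. Compound 2 `Cc1ccc(S(=O)(=O)Nc2cccc(-c3nc(-c4ccc(NC(=O)c5cccnc5)cc4Cl)no3)c2)cc1` likewise gives only a limit, > 10000 nM. All three sit at the limit of > 10000 nM in this assay, at which 3 of the 3 values shown sit, so the steps a step that the two limits leave unreadable from compound 1 to compound 2, a step that the two limits leave unreadable from compound 1 to compound 3 and a step that the two limits leave unreadable from compound 2 to compound 3 cannot be read in size or direction. Compound 4 `CC(=O)Nc1ccc(S(=O)(=O)Nc2cccc(-c3nc(-c4ccc(NC(=O)c5cccnc5)cc4Cl)no3)c2)cc1C` differs from compound 3 in one place: methyl in place of chloro on an aromatic carbon. For the measured compounds named here, no measured step shows what a change of this kind does here, so no direction can be expected from the data. Compound 4 is estimated at 20000 nM, between 8000 nM and 60000 nM, a step that the limit leaves unreadable from compound 3 to compound 4 that is expected to stay at the limit.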

Compound 4, half-maximal inhibitory concentration: > 10000 nM
Compound 4: no number, only a limit (the forecaster's own chance of this, stated with the estimate: 85%); the middle value does not contradict the limit.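

For the compounds shown here, compound 4 gives only a limit, as do compound 1, compound 2 and compound 3, so no step to compound 4 can be read in size or direction: the limit of > 10000 nM in this assay, at which 4 of the 4 values shown sit. Which change to the shared core would give a readable number in this assay stays open.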